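Changing Where the Pyridazine Ring Is Attached

This account rests on a few compounds, and the source may have more. Where it says the series, first, only, none or still open, it means among the compounds named here.

In a functional assay for antagonist activity at Neuropeptide Y receptor type 5 (Homo sapiens) (on this read-out higher numbers stand for weaker inhibition and lower numbers for stronger inhibition), the measured compounds are:
Compound 1 `O=C1O[C@]2(CC[C@H](CNc3cnn(-c4ccccc4F)c3)CC2)CN1c1cncnc1`: 0.0398 nM
Compound 2 `O=C1O[C@]2(CC[C@H](CNc3cnn(-c4ccccc4F)c3)CC2)CN1c1cccnn1`: 0.1 nM
Compound 3 `O=C1O[C@]2(CC[C@H](CNc3ccc(OC4CCC4)cn3)CC2)CN1c1ccccn1`: 0.159 nM

Compound 2 gives the second highest of these three numbers; compound 3 lies within the scatter of it, while compound 1 is clearly lower, the step being a 2.5-fold higher number from compound 1 to compound 2 (0.40 log units; beyond the scatter). Compound 4 `O=C1O[C@]2(CC[C@H](CNc3cnn(-c4ccccc4F)c3)CC2)CN1c1ccnnc1` keeps the atoms of compound 2 but joins them differently: pyridazin-4-yl in place of pyridazin-3-yl on an amide-type nitrogen in a ring. Going by the values given here, only the step from compound 1 to compound 2 bears on this, since it also swapped the ring on that nitrogen and moved the number modestly. A step of similar or smaller size is therefore expected, most likely toward the lower side, though a result within the scatter would not surprise. Compound 4 is estimated at 0.06 nM (range 0.02 nM to 0.2 nM), which means an expected step of a 1.7-fold lower number from compound 2 to compound 4 (0.22 log units; within the scatter).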

Compound 4, inhibition constant: 0.2 nM
Compound 4: middle estimate off by 3.3-fold (0.52 log units), on the low side; measured number inside the range.
By their numbers in this assay, from the lowest: compound 1; then compounds 2, 3 and 4 (each within the scatter of the next).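

Joining the pyridazine ring through a different atom gives a 2.0-fold higher number from compound 2 to compound 4 (0.30 log units; within the scatter) in this assay, so pyridazin-3-yl and pyridazin-4-yl cannot be told apart at this position. Pyridazin-4-yl in place of pyrimidin-5-yl gives a 5.0-fold higher number from compound 1 to compound 4 (0.70 log units; beyond the scatter), so both pyridazine attachments read higher than the pyrimidin-5-yl ring on this core. No supporting data bear on the reason for this difference. The compounds shown leave open how pyrazin-2-yl would read at this position, and whether an amine on the pyrimidin-5-yl ring would change its number.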